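Adding a Second Chloro Group to a Chlorophenyl Ring

A few compounds are considered here, and "the series" means these few. Any claim that something is new, unique, unknown or untested is made for them only; others in the source may bear on it.

Compound 1, `Cc1ccsc1/C=C(/SCc1ccc(Cl)cc1)C(=O)c1ccc(Cl)cc1`: 50000 nM
Compound 2, `Cc1ccsc1/C=C(/SCc1ccc(Cl)cc1Cl)C(=O)c1ccc(Cl)cc1`: 10000 nM
Compound 3, `O=C(/C(=C\c1ccc(Cl)cc1)Sc1ccc(Br)cc1)c1ccc(Br)cc1`: 1000 nM

All three were tested in a functional assay on DU-145 cells (Homo sapiens) for inhibition, read by trypan blue exclusion, with a stated time of 96 h (on this read-out lower numbers stand for stronger inhibition of growth and higher numbers for weaker inhibition of growth), and the numbers above are those growth-inhibition values. Compound 1 and compound 2 share a core and differ in one place: chloro in place of hydrogen on an aromatic carbon. That single change gave a 5.0-fold lower number from compound 1 to compound 2 (0.70 log units; beyond the scatter). Compound 3 sits on a different core, and the difference between the two cores is not broken down here; in this assay compound 3 gives the lowest of the three numbers.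

Compound 4, `O=C(/C(=C\c1ccc(Cl)cc1Cl)Sc1ccc(Br)cc1)c1ccc(Br)cc1`, is not yet measured. Among the measured compounds shown here, it differs from compound 3 by chloro in place of hydrogen on an aromatic carbon, which is the same change as the one between compound 1 and compound 2, with the surroundings of the place described in the same words. If the change behaves on the core of compound 3 as it did before, compound 4 is expected to show a 3.3-fold lower number from compound 3 to compound 4 (0.52 log units; beyond the scatter), resting on the step of a 5.0-fold lower number from compound 1 to compound 2 (0.70 log units; beyond the scatter). For compound 4 the estimated value in this assay is 300 nM, with a likely range from 80 nM to 1200 nM.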

Compound 4, concentration for 50% growth inhibition: 1000 nM
Estimate against measurement, compound 4: 3.3-fold (0.52 log units) below, within the range that was stated.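

In this assay, the chloro group that lowered the number on the core of compound 1 gave no change at the digits printed from compound 3 to compound 4 (within the scatter), so the gain seen on one core did not carry over to the other: the same change on two cores in this assay, a 5.0-fold lower number (0.70 log units; beyond the scatter) from compound 1 to compound 2 and no change at the digits printed (within the scatter) from compound 3 to compound 4, 5.0-fold (0.70 log units) apart, beyond the scatter of two such steps. For a newcomer, the lesson is that a step measured on one core is only a hypothesis for another core, and here the same change behaved differently on two of them. These two pairs do not show why the outcomes differ, since the cores differ in more than one place and nothing here separates those differences, nor do they show how the change would behave on any further core.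

As far as these compounds go, it remains open whether another group in the same place, such as a fluoro, methyl or methoxy group, would move the number on the core of compound 3. From the compounds shown here alone, it is also open whether an amine or a carboxylic acid there would do so.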